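A pyridinyl group exchanged on compound 2

A few compounds are considered here, and "the series" means these few. Any claim that something is new, unique, unknown or untested is made for them only; others in the source may bear on it.

- Compound 1 (`C[C@H](NC(=O)c1ccc(-c2ccc(N)nc2)cc1)C(=O)Nc1ccc(Cl)c(C(F)(F)F)c1`) gives 5950 nM
- Compound 2 (`CC(=O)Nc1ccc(-c2cccc(C(=O)N[C@H]3CN[C@@H](C(=O)Nc4ccc(Cl)c(C(F)(F)F)c4)C3)c2)cn1`) gives 8710 nM

In a functional assay on K562 cells (Homo sapiens) for inhibition, read by MTT assay, with a stated time of 48 h (on this read-out lower numbers stand for stronger inhibition and higher numbers for weaker inhibition), compound 2 stands at 8710 nM and compound 1 at 5950 nM on this read-out, within the scatter of each other. Compound 3 (`O=C(NC1CC1)c1cncc(-c2cccc(C(=O)N[C@H]3CN[C@@H](C(=O)Nc4ccc(Cl)c(C(F)(F)F)c4)C3)c2)c1`) carries 5-(cyclopropylcarbamoyl)pyridin-3-yl in place of 6-acetamidopyridin-3-yl on an aromatic carbon. Going by the values given here, no measured pair differs in one place only, and no shift beyond the scatter is expected in this assay for this exchange. The estimate amounts to an expected 1.2-fold lower number from compound 2 to compound 3 (0.06 log units; within the scatter) and nothing larger. The estimated value for compound 3 is 7500 nM (expected range 3000 nM to 18000 nM).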

Compound 3, half-maximal inhibitory concentration: 27300 nM
Compound 3: middle estimate off by 3.6-fold (0.56 log units), on the low side; the whole stated range lies below it.
By their numbers in this assay, from the lowest: compounds 1 and 2 (each within the scatter of the next); then compound 3.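

In this assay the exchange of 6-acetamidopyridin-3-yl for 5-(cyclopropylcarbamoyl)pyridin-3-yl gives a 3.1-fold higher number from compound 2 to compound 3 (0.50 log units; beyond the scatter) and so weakens inhibition. This shows that the group on this aromatic carbon can shift the read-out beyond the scatter, although the step is modest and rests on this single pair. Nothing at hand explains the step. The compounds shown leave open whether the cyclopropylcarbamoyl group itself or its place on the pyridinyl ring carries this change. They also leave open how a carboxylic acid or a methylcarbamoyl group on that ring would read.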